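The source may hold more compounds than are shown below. What is called first, only, known or untested is meant among the compounds shown, and "the series" means these compounds.

Measured in a functional assay on KB cells (Homo sapiens) for antiproliferative activity, read by MTT assay, with a stated time of 48 h; a lower number here means a stronger inhibitor, a higher number a weaker inhibitor:
- compound 1 `Cc1c(Cc2ccccc2)c(=O)oc2cc(OCCOc3no[n+]([O-])c3S(=O)(=O)c3ccccc3)ccc12`: 4540 nM
- compound 2 `COc1cc(OCCOc2no[n+]([O-])c2S(=O)(=O)c2ccccc2)ccc1C(=O)/C=C/c1ccccc1`: 2180 nM
- compound 3 `Cc1c(Cc2ccc(F)cc2)c(=O)oc2cc(OCCOc3no[n+]([O-])c3S(=O)(=O)c3ccccc3)ccc12`: 3230 nM

Compound 3, at 3230 nM, lies within the scatter of both compound 1 and compound 2, so neither comparison sets it apart.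

Compound 4 `CNS(=O)(=O)Nc1cccc(Cc2c(C)c3ccc(OCCOc4no[n+]([O-])c4S(=O)(=O)c4ccccc4)cc3oc2=O)c1` keeps the core of compound 3 and changes only the aromatic group on the saturated chain carbon. It carries 3-((methylsulfamoyl)amino)phenyl in place of 4-fluorophenyl on a saturated chain carbon bound to an aromatic carbon.

Among the measured compounds shown here, only one measured step bears on this change: a 1.4-fold lower number from compound 1 to compound 3 (0.15 log units; within the scatter), for fluoro in place of hydrogen on an aromatic carbon. For the measured compounds named here, that step lies within the scatter, but it is a much smaller structural change than the one in compound 4. Going by the values given here, no measured compound carries a methylsulfamoyl amino group, so the data offer only weak guidance and give no firm direction. In this assay, no step beyond the scatter is therefore expected, although the uncertainty is wide on both sides. The estimated step is a 1.3-fold lower number from compound 3 to compound 4 (0.11 log units; within the scatter). For compound 4 the estimated value is 2500 nM, with an expected range from 700 nM to 6500 nM.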

Compound 4, half-maximal inhibitory concentration: 1140 nM
Compound 4: middle estimate off by 2.2-fold (0.34 log units), on the high side, and the stated range covers the measured number.
By their numbers in this assay, from the lowest: compounds 4, 2, 3 and 1 (each within the scatter of the next, the first and the last beyond it).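

In this assay, among the compounds shown here, the aromatic group on the saturated chain carbon bound to an aromatic carbon proves able to move the number beyond the scatter, with 3-((methylsulfamoyl)amino)phenyl in place of 4-fluorophenyl giving the first such change at this position (a 2.8-fold lower number from compound 3 to compound 4 (0.45 log units; beyond the scatter)). The comparison with the compound lacking any group on that ring points the same way when the (methylsulfamoyl)amino group is added (a 4.0-fold lower number from compound 1 to compound 4 (0.60 log units; beyond the scatter)), whereas adding a fluoro group had stayed within the scatter (a 1.4-fold lower number from compound 1 to compound 3 (0.15 log units; within the scatter)), so this position responds to some replacements on the ring and not to all. Nothing available here accounts for the lower number, and the change remains an observation without an explanation.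

The compounds shown leave open which part of the new group matters, since a plain amine, a methanesulfonyl amide or a sulfamoyl amino group without the methyl on the same ring would begin to separate its pieces. They also leave open whether the (methylsulfamoyl)amino group would give a similar step on the different core of compound 2.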